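Aryl Swap on the Sulfonamide Nitrogen: Ethyl Out, Bromine In

The source may report more compounds than this note shows. Statements on the series, on what has been measured and on what is new or still open speak of the compounds shown alone.

Three measured compounds share one core and differ only in the aryl group on the sulfonamide nitrogen. In a functional assay on MCF7 cells (Homo sapiens) for antiproliferative activity, read by sulforhodamine B assay, with a stated time of 48 h (on this read-out lower numbers stand for stronger inhibition and higher numbers for weaker inhibition), compound 1 `CCc1ccccc1NS(=O)(=O)c1ccc(N2CCNC2=O)cc1` gives 350 nM, the second highest of the three numbers. In this assay compound 2 `O=C1NCCN1c1ccc(S(=O)(=O)Nc2ccc3[nH]ccc3c2)cc1` gives 170 nM, and compound 3 `O=C1NCCN1c1ccc(S(=O)(=O)Nc2ccccc2)cc1` gives 470 nM. Among the measured compounds shown here, the only single-change step, a 1.3-fold higher number from compound 1 to compound 3 (0.13 log units; within the scatter), stays within the scatter. Compound 4 `O=C1NCCN1c1ccc(S(=O)(=O)Nc2cccc(Br)c2)cc1` carries 3-bromophenyl in place of 2-ethylphenyl on a sulfonamide nitrogen. For the measured compounds named here, no measured step shows what bromine does on this ring. Because the step of a 1.3-fold higher number from compound 1 to compound 3 (0.13 log units; within the scatter) hardly moved the number, compound 4 is expected to change by a 1.1-fold higher number from compound 1 to compound 4 (0.06 log units; within the scatter), a step within the scatter. Compound 4 is therefore estimated at 400 nM, between 150 nM and 1000 nM.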

Compound 4, half-maximal inhibitory concentration: 100 nM
Beside the measured number, compound 4's estimate is 4.0-fold (0.60 log units) above it, outside the stated range (below it).
By their numbers in this assay, from the lowest: compounds 4 and 2 (each within the scatter of the next); then compounds 1 and 3 (each within the scatter of the next).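

Bromo in place of hydrogen on an aromatic carbon gives a 4.7-fold lower number from compound 3 to compound 4 (0.67 log units; beyond the scatter) in this assay, the first single change on this ring shown to move the number beyond the scatter. Replacing 2-ethylphenyl with 3-bromophenyl on a sulfonamide nitrogen likewise gives a 3.5-fold lower number from compound 1 to compound 4 (0.54 log units; beyond the scatter) and brings compound 4 within the scatter of compound 2. No evidence given here accounts for these steps. The compounds shown leave open whether chlorine, a methoxy group, an amine or a carboxylic acid in place of the bromine would give a similar number.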